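Working notes: oxygen alkylation steps in a cytotoxicity series

The source may hold more compounds than are shown below. What is called first, only, known or untested is meant among the compounds shown, and "the series" means these compounds.

Measured compounds:
Compound 1: `C=CC(C)(C/C=C(\C)CCC=C(C)C)c1ccc(O)c(O)c1` — 6.17 ug/mL
Compound 2: `C=CC(C)(C/C=C(\C)CCC=C(C)C)c1ccc(O)c(OCc2ccccc2)c1` — 12.4 ug/mL

In a functional assay on HL-60 cells (Homo sapiens) for cytotoxicity, read by MTT assay, with a stated time of 72 h (on this read-out higher numbers stand for weaker inhibition and lower numbers for stronger inhibition), compound 1 gives 6.17 ug/mL, and its nearest neighbour, compound 2, gives 12.4 ug/mL; the two numbers stand within the scatter of each other, so no order between them can be claimed. Among the compounds with values here, the one measured step, a 2.0-fold higher number from compound 1 to compound 2 (0.30 log units; within the scatter), comes from putting benzyl in place of hydrogen on one ring oxygen of the shared core.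

Compound 3 is `C=CC(C)(C/C=C(\C)CCC=C(C)C)c1ccc(OC)c(O)c1`. It differs from compound 1 by methyl in place of hydrogen on an oxygen on an aromatic ring. Within the data shown here, the only measured step that bears on it is the alkylation step a 2.0-fold higher number from compound 1 to compound 2 (0.30 log units; within the scatter), which stayed within the scatter; a methyl on the other ring oxygen is a smaller change of the same kind. Compound 3 is therefore expected to show a 1.3-fold higher number from compound 1 to compound 3 (0.11 log units; within the scatter), that is, no step beyond the scatter. Compound 3 is estimated at 8 ug/mL, with a range from 3.5 ug/mL to 18 ug/mL.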

Compound 3, half-maximal inhibitory concentration: 18.8 ug/mL
Estimate against measurement, compound 3: 2.4-fold (0.37 log units) below, outside the stated range (above it).
By their numbers in this assay, from the lowest: compounds 1, 2 and 3 (each within the scatter of the next, the first and the last beyond it).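

In this assay, within the data shown here, hydroxy to methoxy on the ring oxygen alkylated in compound 3 gives a 3.0-fold higher number from compound 1 to compound 3 (0.48 log units; beyond the scatter) and so forms the first alkylation step to pass the scatter, though only modestly. On this oxygen a single methyl is enough for a readable step, whereas a 2.0-fold higher number from compound 1 to compound 2 (0.30 log units; within the scatter) on the other ring oxygen stays within the scatter. No measured evidence bears on what sets the size of this step.

The two steps change both the group and the oxygen that carries it, so the compounds shown leave open which of the two matters. Also open, from the compounds shown here alone, is whether a longer chain such as propyl, or an ether carrying a carboxylic acid, on this oxygen would extend the methyl step.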